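Phenyl in place of pentan-3-yl: compound 3 to compound 4

This account rests on a few compounds, and the source may have more. Where it says the series, first, only, none or still open, it means among the compounds named here.

- compound 1 `CCCCCCOc1cccc(O)c1C(=O)/C=C/c1ccc(O)cc1`: > 30000 nM
- compound 2 `CC(C)(C)CCOc1cccc(O)c1C(=O)/C=C/c1ccc(O)cc1`: 2380 nM
- compound 3 `CCC(CC)COc1cccc(O)c1C(=O)/C=C/c1ccc(O)cc1`: 3130 nM

These values come from a functional assay on MDA-MB-231 cells (Homo sapiens) for antiproliferative activity, read by sulforhodamine B assay; on this read-out higher numbers stand for weaker inhibition of growth and lower numbers for stronger inhibition of growth. The entry for compound 1 is a limit and not a number.

Compound 3 has one numerical neighbour, and the data show a 1.3-fold higher number from compound 2 to compound 3 (0.12 log units; within the scatter). The next compound, compound 4 `O=C(/C=C/c1ccc(O)cc1)c1c(O)cccc1OCc1ccccc1`, differs from it as follows: phenyl in place of pentan-3-yl on a saturated chain carbon bound to an oxygen on an aromatic ring.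

Three measured steps change this same side chain. The step between the two branched chains is the one above, but the others are far wider: an at least 12-fold lower number from compound 1 to compound 2 (1.10 log units; beyond the scatter), and an at least 9.5-fold lower number from compound 1 to compound 3 (0.98 log units; beyond the scatter). Changes here can therefore do little or a great deal, and none of the measured chains carries a ring. From the position of compound 3, a modest move towards weaker inhibition of growth seems the likeliest outcome, with wide uncertainty. The expected change is a 2.2-fold higher number from compound 3 to compound 4 (0.35 log units; beyond the scatter). For compound 4 the estimated value in this assay is 7000 nM, with an expected range of 2000 nM to 30000 nM.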

Compound 4, concentration for 50% growth inhibition: > 30000 nM
Compound 4 was reported as a limit (the forecaster's own chance of this, stated with the estimate: 20%); middle value at least 4.2-fold (0.63 log units) away from the limit.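

In this assay, among the compounds shown here, phenyl in place of pentan-3-yl puts a ring at this place for the first time, and the change gives an at least 9.5-fold higher number from compound 3 to compound 4 (0.98 log units; beyond the scatter), while phenyl in place of neopentyl gives an at least 12-fold higher number from compound 2 to compound 4 (1.10 log units; beyond the scatter). So the two branched chains are separated from the phenyl by steps well beyond the scatter, although the side chain grows only from 5 to 6 heavy atoms in the first of these changes. Compound 4 is reported only as a limit, as compound 1 is, and the step between these two cannot be read: the limit of > 30000 nM in this assay, at which 2 of the 4 values shown sit.

As far as these compounds go, how far compound 4 lies past its limit stays unknown. The compounds shown also leave open whether the ring itself or its direct attachment to the chain carbon matters, which cyclohexyl or 2-phenylethyl at this place could separate.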